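The source may report more compounds than this note shows. Statements on the series, on what has been measured and on what is new or still open speak of the compounds shown alone.

The three measured compounds share one core and differ only in their ester groups. Compound 1 `Cc1oc(=O)oc1COC(=O)C1=C(S[C@@H]2CN[C@H](C(=O)Nc3cccc(C(=O)OCc4oc(=O)oc4C)c3)C2)[C@H](C)[C@@H]2[C@@H]([C@@H](C)O)C(=O)N12`, compound 2 `C[C@@H](O)[C@H]1C(=O)N2C(C(=O)OCOC(=O)C(C)(C)C)=C(S[C@@H]3CN[C@H](C(=O)Nc4cccc(C(=O)OCOC(=O)C(C)(C)C)c4)C3)[C@H](C)[C@H]12` and compound 3 `C[C@@H](O)[C@H]1C(=O)N2C(C(=O)OCOC(=O)C(C)(C)C)=C(S[C@@H]3CN[C@H](C(=O)Nc4cccc(C(=O)O)c4)C3)[C@H](C)[C@H]12` were all tested in an ADME assay for metabolic stability, read by LC-MS, with a stated time of 3 h, at pH 6.5, tested at 50 uM; a lower number here means that less of the compound is left, a higher number that more of the compound is left. In this assay compound 1 gives > 95%, which is a limit of the assay rather than a number. Compound 2 likewise gives > 95% in this assay, again a limit. Compound 3 gives > 95% in this assay, also a limit. Among the compounds with values here, the only step between neighbours, a step that the two limits leave unreadable from compound 2 to compound 3, in which hydrogen replaces (((tert-butyl)carbonyl)oxy)methyl on an oxygen next to a carbonyl group, therefore cannot be sized. Compound 3 thus stands at the limit together with the other two, as the limit of > 95% in this assay, at which 3 of the 3 values shown sit, records.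

Compound 4 `CCC(CC)C(=O)OCOC(=O)C1=C(S[C@@H]2CN[C@H](C(=O)Nc3cccc(C(=O)O)c3)C2)[C@H](C)[C@@H]2[C@@H]([C@@H](C)O)C(=O)N12` differs from compound 3 in one place: pentan-3-yl in place of tert-butyl on a carbonyl carbon. Within the data shown here, no measured step bears on this carbonyl carbon, and the one step available is unreadable, so nothing in the data points to a change in either direction. Compound 4 is therefore expected to remain at the limit, with an estimated value of 96% in this assay, between 85% and 100%. The expected step that the limit leaves unreadable from compound 3 to compound 4 is estimated to be none beyond the scatter.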

Compound 4, percent of the compound remaining: > 95%
Compound 4 ended at the assay's limit (the forecaster's own chance of this, stated with the estimate: 75%); the middle value does not contradict the limit.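

No new step can be read between compound 3 and compound 4, which differ by pentan-3-yl in place of tert-butyl on a carbonyl carbon, as both stand at a limit of this assay. The compounds shown leave open whether their ester groups differ at all in this assay, as all of them share one mark: the limit of > 95% in this assay, at which 4 of the 4 values shown sit.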